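From Methyl to Methoxy in a Cell Test

The source may hold more compounds than are shown below. What is called first, only, known or untested is meant among the compounds shown, and "the series" means these compounds.

Of the compounds shown here, two have been measured so far. In a functional assay on KG-1 cells (Homo sapiens) for cytotoxicity, read by luminescence and CellTiter-Glo, with a stated time of 3 days (a higher number here means a weaker inhibitor, a lower number a stronger inhibitor), compound 1 (`N#Cc1ccc(NC(=O)c2ccc3cccnc3c2O)c(F)c1`) gives 3260 nM and compound 2 (`Cc1cccc(O)c1C(=O)Nc1ccc(C#N)cc1`) gives 7940 nM as its reading. Compound 2 therefore has the higher of the two numbers, and its gap to compound 1 lies beyond the usual scatter of repeated measurements. On this small set, compound 2 is the weaker inhibitor.

Compound 3 (`COc1cccc(O)c1C(=O)Nc1ccc(C#N)cc1`) differs from compound 2 in one place: methoxy in place of methyl on an aromatic carbon that is ortho to a large group and meta to a hydroxy group. Going by the values given here, no measured pair shows this exchange, so the data offer no direct guide to its effect. With a single small group exchanged and the rest of the structure unchanged, a modest result seems the sensible expectation. In this assay the estimated change is a 1.1-fold lower number from compound 2 to compound 3 (0.05 log units; within the scatter) and no shift beyond the scatter is expected in either direction. For compound 3 the expected value is 7000 nM with an estimated range from 2500 nM to 20000 nM at this stage.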

Compound 3, half-maximal inhibitory concentration: > 10000 nM
Compound 3: a limit, no number (the forecaster's own chance of this, stated with the estimate: 10%); middle value at least 1.4-fold (0.15 log units) away from the limit.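

In this assay compound 3 gives > 10000 nM as its reading, which is a limit of the assay and not a number. Methoxy in place of methyl on this aromatic carbon, ortho to a large group and meta to a hydroxy group, comes with an at least 1.2-fold higher number from compound 2 to compound 3 (0.10 log units; that floor lies within the scatter) and so gives no lower number in this cell test, a first view of this position that the earlier compounds, which formed no pair differing in one place, could not offer. The size of this step is only a floor, and the reading of compound 3 sits at the edge of what the test reports: the limit of > 10000 nM in this assay, at which 1 of the 3 values shown sits.

The compounds shown leave open how far past the limit compound 3 really lies, and so whether the true step from methyl to methoxy goes beyond the scatter or stays within it. They also leave open what an amine, a chlorine atom or a longer chain would do on this same aromatic carbon, and whether any group there can give a clearly lower number.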